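A few compounds are considered here, and "the series" means these few. Any claim that something is new, unique, unknown or untested is made for them only; others in the source may bear on it.

Of the compounds shown here, three built on the shared core have been measured in an assay on isolated protein for inhibition of Fatty-acid amide hydrolase 1 (Homo sapiens), read by fluorescence, with a stated time of 30 min; a lower number here means a stronger inhibitor, a higher number a weaker inhibitor. Compound 1 `CCOC(=O)c1cc(-c2cccc(OC(=O)NC3CCCCC3)c2)n(C)n1` gives 303 nM. Compound 2 `CCOC(=O)c1cc(-c2cccc(OC(=O)NC3CCCCC3)c2)n(CC)n1` gives 101 nM, and the change from compound 1 to compound 2 (a 3.0-fold lower number from compound 1 to compound 2 (0.48 log units; beyond the scatter)) is a modest step. Compound 3 `CCOC(=O)c1cc(-c2cccc(OC(=O)NC3CCCCC3)c2)n(-c2ccc(OC)cc2)n1` gives 103 nM; its step from compound 1 (a 2.9-fold lower number from compound 1 to compound 3 (0.47 log units; beyond the scatter)) is of similar size, while the comparison from compound 2 to compound 3 (a 1.0-fold higher number from compound 2 to compound 3 (0.01 log units; within the scatter)) shows no difference beyond the scatter. Compound 3 therefore sits with compound 2, apart from compound 1 only.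

Compound 4 `CCOC(=O)c1cc(-c2cccc(OC(=O)NC3CCCCC3)c2)n(-c2ccc(C)cc2)n1` is not yet measured. It differs from compound 3 by methyl in place of methoxy on an aromatic carbon; seen one bond further out, this is 4-methoxyphenyl to 4-methylphenyl. For the measured compounds named here, no measured step alters a group on this outer ring, so none bears on it directly. Going by the values given here, the only related evidence is that swapping ethyl for 4-methoxyphenyl (a 1.0-fold higher number from compound 2 to compound 3 (0.01 log units; within the scatter)) changed nothing beyond the scatter, which suggests this position is tolerant. Compound 4 is thus expected to show a 1.0-fold higher number from compound 3 to compound 4 (0.01 log units; within the scatter), with an estimated value of 105 nM in this assay, in a range of 50 nM to 220 nM.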

Compound 4, half-maximal inhibitory concentration: 29 nM
Compound 4: the middle estimate sits 3.6-fold (0.56 log units) above what was measured; the whole stated range lies above it.
By their numbers in this assay, from the lowest: compound 4; then compounds 2 and 3 (each within the scatter of the next); then compound 1.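

Before this result, ethyl and 4-methoxyphenyl on the aromatic nitrogen could not be told apart, which made that site look indifferent to what it carries. Exchanging methoxy for methyl, para to a large group, now gives a clear gain (a 3.6-fold lower number from compound 3 to compound 4 (0.55 log units; beyond the scatter)), so the small group on this outer ring matters, and not merely the presence of a ring. The 4-methylphenyl group also separates from ethyl (a 3.5-fold lower number from compound 2 to compound 4 (0.54 log units; beyond the scatter)) and gives the only large step in the set (a 10-fold lower number from compound 1 to compound 4 (1.02 log units; beyond the scatter)), though nothing shown explains why methyl differs from methoxy here.

Two groups at this ring carbon give no trend. From the compounds shown here alone, how a chlorine atom, a hydroxyl, an amine or a longer chain such as ethyl would read at this place remains open.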